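Acid to amino-ester: reversing a potency loss

This account rests on a few compounds, and the source may have more. Where it says the series, first, only, none or still open, it means among the compounds named here.

Compound 1 `Nc1ccc(-c2cc(=O)c3c(N)c(F)c(CO)c(F)c3o2)cc1F` gives 62 nM in a functional assay on MCF7 cells (Homo sapiens) for cytotoxicity, read by neutral red uptake, with a stated time of 3 days; a lower number here means a stronger inhibitor, a higher number a weaker inhibitor. For compound 2 `Nc1ccc(-c2cc(=O)c3c(N)c(F)c(C(=O)O)c(F)c3o2)cc1F` the same assay reports only a limit, > 10000 nM, and the limit of > 10000 nM in this assay, at which 1 of the 2 values shown sits, shows it is one of two values there. For the measured compounds named here, the only measured step, an at least 160-fold higher number from compound 1 to compound 2 (2.20 log units; beyond the scatter), is large and beyond the scatter. Compound 3 `CN(C)CC(=O)OCc1c(F)c(N)c2c(=O)cc(-c3ccc(N)c(F)c3)oc2c1F` removes that carboxy: ((((dimethylamino)methyl)carbonyl)oxy)methyl in place of carboxy on an aromatic carbon. Because the step of an at least 160-fold higher number from compound 1 to compound 2 (2.20 log units; beyond the scatter) was caused by adding the carboxy, undoing it is expected to recover most of the lost potency, giving the step of an at least 66-fold lower number from compound 2 to compound 3 (1.82 log units; beyond the scatter) as an estimate. Compound 3 is therefore expected near 150 nM, between 30 nM and 1500 nM.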

Compound 3, half-maximal inhibitory concentration: 26 nM
For compound 3 the middle estimate is 5.8-fold (0.76 log units) above the measured one; measured number below the stated range.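

On the shared core, this position accepts a much larger group than hydroxymethyl: adding ((dimethylamino)methyl)carbonyl to the hydroxymethyl oxygen gives a 2.4-fold lower number from compound 1 to compound 3 (0.38 log units; beyond the scatter). Replacing the carboxy with ((((dimethylamino)methyl)carbonyl)oxy)methyl gives an at least 380-fold lower number from compound 2 to compound 3 (2.58 log units; beyond the scatter), so the weak result goes with the carboxy, not with every larger group here. Compound 2 has only a limit, which makes that step a bound rather than an exact size: the limit of > 10000 nM in this assay, at which 1 of the 3 values shown sits.

On these data alone, it remains open whether the dimethylamino group matters, as a simple acetyl ester would test. Also open, as far as these compounds go, is whether compound 3 acts intact or after losing its ester.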